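The compounds below may be only part of what the source reports. "The series", "measured", "known", "first", "only" and "open" are said of these compounds alone.

Measured so far:
compound 1 `Cn1c(=O)c2nc(-c3ccc(Cl)cc3)[nH]c2n(C)c1=O` — in an assay on isolated protein for binding affinity to adenosine receptor A1 (Rattus norvegicus) (a lower number here means a stronger inhibitor, a higher number a weaker inhibitor), compound 1 gives 0.646 nM
compound 2 `Cc1ccc(-c2nc3c(=O)n(C)c(=O)n(C)c3[nH]2)cc1` — in this assay compound 2 gives 0.513 nM

For the measured compounds named here, compound 2 stands beside compound 1, the only other measured compound, and the step of a 1.3-fold lower number from compound 1 to compound 2 (0.10 log units; within the scatter) separates them by less than the scatter. Compound 3 `Cn1c(=O)c2nc(-c3ccc(F)cc3)[nH]c2n(C)c1=O` differs from compound 2 by fluoro in place of methyl on an aromatic carbon. Going by the values given here, the only step bearing on this position is a 1.3-fold lower number from compound 1 to compound 2 (0.10 log units; within the scatter), which is small; a swap of one small group for another at the same carbon is therefore not expected to move the number beyond the scatter. The expected step is a 1.6-fold higher number from compound 2 to compound 3 (0.19 log units; within the scatter). Compound 3 is estimated at 0.8 nM, within 0.35 nM to 2 nM.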

Compound 3, inhibition constant: 1.82 nM
For compound 3 the middle estimate is 2.3-fold (0.36 log units) below the measured one; measured number inside the range.
By their numbers in this assay, from the lowest: compounds 2 and 1 (each within the scatter of the next); then compound 3.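

In this assay the aromatic carbon para to a large group proves sensitive to the choice of group: fluoro in place of methyl gives a 3.5-fold higher number from compound 2 to compound 3 (0.55 log units; beyond the scatter), and fluoro in place of chloro gives a 2.8-fold higher number from compound 1 to compound 3 (0.45 log units; beyond the scatter). Both steps are modest, but they set fluoro apart from methyl and chloro, which stay within the scatter of each other. Nothing available accounts for this separation. As far as these compounds go, whether bromo, methoxy or an amine on this carbon would read like methyl and chloro or like fluoro remains open.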